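Cyclohexyl for propyl on the triazole nitrogen of compound 1

The compounds below may be only part of what the source reports. "The series", "measured", "known", "first", "only" and "open" are said of these compounds alone.

Measured so far:
compound 1 `CCCn1cc(COc2cc(O)c3c(c2)O[C@H](c2ccc(OC)c(O)c2)CC3=O)nn1` — 9670 nM
compound 2 `COc1ccc([C@@H]2CC(=O)c3c(O)cc(OCc4cn(Cc5ccccc5Cl)nn4)cc3O2)cc1O` — 6140 nM
compound 3 `COc1ccc([C@@H]2CC(=O)c3c(O)cc(OCc4cn(C)nn4)cc3O2)cc1O` — 15200 nM

In a functional assay on RAW264.7 cells (Mus musculus) for inhibition, read by Griess assay, with stated times of 2 h and 24 h (on this read-out higher numbers stand for weaker inhibition and lower numbers for stronger inhibition), compound 1 holds the second highest number of the three. Its nearest neighbour is compound 3, a step of a 1.6-fold higher number from compound 1 to compound 3 (0.20 log units; within the scatter); compound 2 lies the other way, a step of a 1.6-fold lower number from compound 1 to compound 2 (0.20 log units; within the scatter). Within the data shown here, only the step of a 2.5-fold higher number from compound 2 to compound 3 (0.39 log units; beyond the scatter) goes beyond the scatter.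

Compound 4 `COc1ccc([C@@H]2CC(=O)c3c(O)cc(OCc4cn(C5CCCCC5)nn4)cc3O2)cc1O` differs from compound 1 by cyclohexyl in place of propyl on an aromatic nitrogen. The measured steps touch the same position but change the group on a saturated chain carbon bound to the aromatic nitrogen, not the group on the aromatic nitrogen itself, so they bear on the change only loosely. Both were small, and the larger group in compound 2 gave the lower number. A step of a 1.4-fold lower number from compound 1 to compound 4 (0.14 log units; within the scatter) is therefore expected, within the scatter. Compound 4 is estimated at 7000 nM, in the range 3500 nM to 14000 nM.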

Compound 4, half-maximal inhibitory concentration: 15600 nM
The estimate for compound 4 lay 2.2-fold (0.35 log units) below the measured number; measured number outside the range, above it.
By their numbers in this assay, from the lowest: compounds 2, 1, 3 and 4 (each within the scatter of the next, the first and the last beyond it).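

In this assay, cyclohexyl on the aromatic nitrogen cannot be told apart from propyl (a 1.6-fold higher number from compound 1 to compound 4 (0.21 log units; within the scatter)) or from methyl (a 1.0-fold higher number from compound 3 to compound 4 (0.01 log units; within the scatter)), so more carbon at this position does not by itself go with a lower number. Against 2-chlorobenzyl the gap is beyond the scatter (a 2.5-fold higher number from compound 2 to compound 4 (0.40 log units; beyond the scatter)), which shows that a large group here does not always behave like the one in compound 2. Nothing shown gives a reason for this.

From the compounds shown here alone, whether benzyl without the chlorine would match compound 2 stays open. So does the effect of a group carrying an amine or a carboxylic acid at this position.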